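The source may report more compounds than this note shows. Statements on the series, on what has been measured and on what is new or still open speak of the compounds shown alone.

In an ADME assay on HepG2 cells (Homo sapiens) for cytotoxicity, read by MTT assay, with a stated time of 72 h (a lower number here means that less compound is tolerated, a higher number that more compound is tolerated), compound 3 (`O=[N+]([O-])c1c(CS(=O)(=O)c2ccccc2)nc2c(-c3ccc(F)cc3)cc(Cl)cn12`) gives > 15600 nM as a limit, not a number. Compound 1 (`CCN(CC)c1ccc(-c2cc(Cl)cn3c([N+](=O)[O-])c(CS(=O)(=O)c4ccccc4)nc23)cc1`) gives > 15600 nM as a limit too. Compound 2 (`O=[N+]([O-])c1c(CS(=O)(=O)c2ccccc2)nc2c(-c3cccc(CO)c3)cc(Cl)cn12`) gives > 25000 nM as a limit too. Compound 4 (`O=[N+]([O-])c1c(CS(=O)(=O)c2ccccc2)nc2c(-c3ccc(F)cc3F)cc(Cl)cn12`) has fluoro in place of hydrogen on an aromatic carbon, the change from 4-fluorophenyl to 2,4-difluorophenyl. Within the data shown here, two measured steps bear on it, a step that the two limits leave unreadable from compound 1 to compound 3 and a step that the two limits leave unreadable from compound 2 to compound 3, and neither gives a size. The values shown sit at the limit of > 15600 nM in this assay, at which 2 of the 3 values shown sit, and at the limit of > 25000 nM in this assay, at which 1 of the 3 values shown sits, in this assay, and none is a number. Nothing beyond the scatter is therefore expected, in either direction, for the estimated step that the limit leaves unreadable from compound 3 to compound 4 here. Compound 4 is estimated at 20000 nM, with an expected range of 10000 nM to 40000 nM, and will probably be reported only as a limit.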

Compound 4, half-maximal cytotoxic concentration: > 7800 nM
Compound 4: only a limit was reported; the forecaster's own chance of this, stated with the estimate: 80%; the middle value lies beyond the limit too.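

Among these compounds, compound 1, compound 2, compound 3 and compound 4 all give only limits in this assay, so no step among them can be read. The compounds shown leave open whether any of these substituent changes alters tolerance at all.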